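The compounds below may be only part of what the source reports. "The series", "measured", "known", "first", "only" and "open" are said of these compounds alone.

Measured compounds in a functional assay on B16-F10 cells (Mus musculus) for antiproliferative activity, read by ELISA and MTT assay, with a stated time of 48 h; a higher number here means a weaker inhibitor, a lower number a stronger inhibitor:
Compound 1, `O=C(/C=C/c1ccccc1)NS(=O)(=O)c1ccccc1`, gives 3.5 ug/mL.
Compound 2, `O=C(/C=C/c1ccc(F)cc1)NS(=O)(=O)c1ccc(Br)cc1`, gives 2.8 ug/mL.
Compound 3, `O=C(/C=C/c1ccc(Cl)cc1)NS(=O)(=O)c1ccccc1`, gives 2.2 ug/mL.

Compound 3 has the lowest of the three numbers in this assay, but its nearest neighbour compound 2 and its furthest neighbour compound 1 both sit within the scatter of it, so no order among the three can be claimed. Among the measured compounds shown here, the one single-point step that is known, a 1.6-fold lower number from compound 1 to compound 3 (0.20 log units; within the scatter), is itself within the scatter.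

Compound 4, `O=C(/C=C/c1ccc(Cl)cc1)NS(=O)(=O)c1ccc(Br)cc1`, differs from compound 3 by bromo in place of hydrogen on an aromatic carbon. For the measured compounds named here, no measured pair isolates this bromo change: compound 2 carries a bromo on the same ring but differs from compound 3 in two places, and its value stands within the scatter of compound 3. Going by the values given here, the chloro step from compound 1 to compound 3 is the only guide, and it was small. On that basis compound 4 is expected to stay within the scatter of compound 3, the estimated step being no change at the digits printed from compound 3 to compound 4 (within the scatter). The estimate for compound 4 in this assay is 2.2 ug/mL, with a range from 1.2 ug/mL to 4 ug/mL.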

Compound 4, half-maximal inhibitory concentration: 2.8 ug/mL
The estimate for compound 4 lay 1.3-fold (0.10 log units) below the measured number; the range from low to high includes it.
By their numbers in this assay, from the lowest: compounds 3, 2, 4 and 1 (each within the scatter of the next).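

In this assay, among the compounds shown here, compound 4 supplies the first measured pair that isolates bromo in place of hydrogen on this aromatic carbon, para to a large group, and the step reads a 1.3-fold higher number from compound 3 to compound 4 (0.10 log units; within the scatter) with no effect that can be claimed for phenyl to 4-bromophenyl. With the bromo held fixed, chloro in place of fluoro gives no change at the digits printed from compound 2 to compound 4 (within the scatter) and so likewise separates nothing among these compounds. No accompanying evidence bears on these results.

The compounds shown leave open whether a group other than a halogen at this position, such as an amine, a carboxylic acid or a methoxy group, would move the number beyond the scatter. They also leave open whether a methyl group on the amide nitrogen or a longer chain in the linker would do so.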